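A few compounds are considered here, and "the series" means these few. Any claim that something is new, unique, unknown or untested is made for them only; others in the source may bear on it.

The three compounds measured so far and their values in an assay on CHO cells for displacement of a labelled ligand from adenosine receptor A1 (Homo sapiens), read by scintillation counting, tested at 10 uM; a higher number here means more inhibition at the concentration tested (going by the name of the read-out), a lower number less inhibition:

compound 1, `CC(C)(C)Cc1c(-c2cccnc2)sc(N)c1C(=O)c1ccc(Cl)cc1`: 1%
compound 2, `Cc1ccc(-c2sc(N)c(C(=O)c3ccc(Cl)cc3)c2CC(C)(C)C)cc1`: 1%
compound 3, `CC(C)(C)Cc1c(Br)sc(N)c1C(=O)c1ccc(Cl)cc1`: 1%

Compound 3 stands level with compounds 1 and 2 at the digits given; the step of no change at the digits printed from compound 1 to compound 3 (within the scatter) and the step of no change at the digits printed from compound 2 to compound 3 (within the scatter) both lie within the scatter, as does the step of no change at the digits printed from compound 1 to compound 2 (within the scatter). All three measured steps swap the group on the aromatic carbon of the shared core, and none of them moved the read-out.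

Compound 4, `CC(C)(C)Cc1c(Br)sc(N)c1C(=O)c1ccc(Cl)c(Cl)c1`, is not yet measured. It differs from compound 3 in this way: chloro in place of hydrogen on an aromatic carbon. Within the data shown here, no measured step touches that six-membered ring of carbon only, so there is no direct precedent for adding a chloro there. Since every change tried so far left the inhibition unmoved, and compound 3 itself gives 1%, the expected step of a number 1 percentage points higher from compound 3 to compound 4 (within the scatter) is none beyond the scatter. Compound 4 is therefore estimated at 2% in this assay, with a range from 0% to 15%.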

Compound 4, a percentage reported as inhibition, at one concentration (the size of the read-out at that concentration, not a potency): 1%
For compound 4 the middle estimate is 1 percentage points above the measured one, within the range that was stated.
By their numbers in this assay, from the lowest: compounds 1, 2, 3 and 4 (each within the scatter of the next).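

In this assay, placing a chloro on the six-membered aromatic ring of carbon only, ortho to the chloro group already there, gives no change at the digits printed from compound 3 to compound 4 (within the scatter) and leaves compound 4 at 1%. This is the first step shown at that ring, so the unmoved read-out now extends beyond the group swaps on the aromatic carbon of the shared core to a second place, although a reading this low could hardly register any further loss. Nothing available explains why the added chloro left the read-out where it was.

The compounds shown leave open whether a methoxy group, an amine or a carboxylic acid on this ring would raise the inhibition. They also leave open whether a longer chain on the shared core would move it.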